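Propyl to furan-2-yl on the shared core

The compounds below may be only part of what the source reports. "The series", "measured", "known", "first", "only" and "open" are said of these compounds alone.

Compound 1 `CCCc1n[nH]c2c(=O)n(NC(=O)c3ccccc3)c(-c3cccc([N+](=O)[O-])c3)nc12` and compound 2 `CCCc1n[nH]c2c(=O)n(NC(=O)c3ccccc3)c(-c3cccc(OC)c3)nc12` share one core and differ only in the group on the pendant aromatic ring. In a functional assay on HT-29 cells (Homo sapiens) for cytotoxicity, read by sulforhodamine B assay, with a stated time of 2 days, tested at 100 uM (on this read-out lower numbers stand for less inhibition and higher numbers for more inhibition at the one concentration tested (going by the name of the read-out)), compound 1 gives 18.7%, the higher of the two numbers shown, and compound 2 gives 6.27%. Among the compounds with values here, the single measured step, a number 12.4 percentage points lower from compound 1 to compound 2 (beyond the scatter), changes the pendant ring, not the alkyl group on the core.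

Compound 3 `O=C(Nn1c(-c2cccc([N+](=O)[O-])c2)nc2c(-c3ccco3)n[nH]c2c1=O)c1ccccc1` is not yet measured. It differs from compound 1 by furan-2-yl in place of propyl on an aromatic carbon. Within the data shown here, no measured step touches this position, so the step from compound 1 to compound 2 does not bear on it directly and gives no direction. With nothing to set a size, the expectation is a step within the usual scatter, a number 0.7 percentage points lower from compound 1 to compound 3 (within the scatter), in either direction. Compound 3 is therefore estimated at 18% in this assay, with a range from 5% to 32%.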

Compound 3, a percentage reported as inhibition, at one concentration (the size of the read-out at that concentration, not a potency): 21.2%
Compound 3: the middle estimate sits 3.2 percentage points below what was measured; the range from low to high includes it.
By their numbers in this assay, from the lowest: compound 2; then compounds 1 and 3 (each within the scatter of the next).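

In this assay, within the data shown here, furan-2-yl in place of propyl on an aromatic carbon of the five-membered aromatic ring gives a number 2.5 percentage points higher from compound 1 to compound 3 (within the scatter) and so provides the first measured step at this position. The entering group brings an aromatic ring and a hydrogen-bond acceptor that propyl lacks, yet this pair is not separated by the read-out, whereas the change on the pendant ring, a number 12.4 percentage points lower from compound 1 to compound 2 (beyond the scatter) in the same assay, is the only step shown beyond the scatter. No supporting data bear on why the furan-2-yl change leaves the read-out within the scatter.

On these data alone, whether an aminomethyl group, a carboxylic acid or a longer alkyl chain at this position would also stay within the scatter remains open. Also open, as far as these compounds go, is whether furan-2-yl gives the same result when methoxy replaces nitro on the pendant ring.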